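Dropping the methoxy from the aryl ether of compound 1

The compounds below may be only part of what the source reports. "The series", "measured", "known", "first", "only" and "open" are said of these compounds alone.

Measured compounds in this test:
compound 1, `COc1ccc(Oc2nc(Nc3ccc(C#N)cc3)nc3ccccc23)cc1`: 340000 nM
compound 2, `Cc1cc(C#N)cc(C)c1Oc1nc(Nc2ccc(C#N)cc2)nc2ccccc12`: 203000 nM
compound 3, `Cc1ccccc1Oc1nc(Nc2ccc(C#N)cc2)nc2ccccc12`: 355000 nM

In an ADME assay on MT4 cells (Homo sapiens) for cytotoxicity, read by MTT assay, with a stated time of 4 days (on this read-out lower numbers stand for higher toxicity in this test and higher numbers for lower toxicity in this test), compound 1 gives 340000 nM, the second highest of the three numbers. Compound 3 lies nearest to it, with a 1.0-fold higher number from compound 1 to compound 3 (0.02 log units; within the scatter), and compound 2 furthest, with a 1.7-fold lower number from compound 1 to compound 2 (0.22 log units; within the scatter); between those two, a 1.7-fold higher number from compound 2 to compound 3 (0.24 log units; within the scatter). Among the compounds with values here, all three numbers therefore sit within the scatter of one another, so no compound can be set apart as more or less toxic.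

Compound 4, `N#Cc1ccc(Nc2nc(Oc3ccccc3)c3ccccc3n2)cc1`, differs from compound 1 by hydrogen in place of methoxy on an aromatic carbon, on an aromatic carbon of a six-membered aromatic ring of carbon only. The two steps that bear on this change, from compound 1 to compound 2 and from compound 1 to compound 3, both swap the aryl group on that same oxygen, and both stayed within the scatter. A smaller alteration of the same ring is therefore expected to do no more: the estimated step is a 1.1-fold lower number from compound 1 to compound 4 (0.03 log units; within the scatter). Compound 4 is expected to give 320000 nM in this assay, within a range of 150000 nM to 650000 nM.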

Compound 4, half-maximal cytotoxic concentration: 370000 nM
Beside the measured number, compound 4's estimate is 1.2-fold (0.06 log units) below it, and the stated range covers the measured number.
By their numbers in this assay, from the lowest: compounds 2, 1, 3 and 4 (each within the scatter of the next).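

Taking the methoxy off the ring, para to a large group, leaves this assay without a readable change (a 1.1-fold higher number from compound 1 to compound 4 (0.04 log units; within the scatter)), whereas the earlier steps exchanged the whole aryl group on that oxygen and so could not show the effect of this one group alone. The unsubstituted phenyl also stays within the scatter of the two methyl-bearing aryl ethers (a 1.0-fold higher number from compound 3 to compound 4 (0.02 log units; within the scatter); a 1.8-fold higher number from compound 2 to compound 4 (0.26 log units; within the scatter)), so a bare ring sets compound 4 apart from neither compound 2 nor compound 3. No measurement offers a reason for this lack of separation.

The compounds shown leave open whether an amine or a carboxylic acid at this place would move the number beyond the scatter. They also leave open whether the same holds once another part of the core of compound 1 is changed.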